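The compounds below may be only part of what the source reports. "The series", "measured", "known", "first", "only" and "open" are said of these compounds alone.

Compound 1 `O=C1CSC(c2cccc(O)c2)N1CCN1CCCCC1` and compound 2 `Cc1ccc(C2SCC(=O)N2CCN2CCCCC2)cc1` share a core that differs only in the aryl group on a saturated ring carbon. In an ADME assay on Vero cells (Chlorocebus sabaeus) for cytotoxicity, read by neutral red uptake, tested at 12.3 ug/mL (a lower number here means a stronger effect, a higher number a weaker effect of the compound at the concentration tested), compound 1 gives 100%. Going by the values given here, compound 2 gives 100% in this assay, so the step of no change at the digits printed from compound 1 to compound 2 (within the scatter) is the only measured step, and it shows no movement beyond the scatter. Compound 2 therefore stands level with compound 1 on the numbers shown; it has no closer neighbour.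

Compound 3 `O=C1CSC(c2cccc(F)c2)N1CCN1CCCCC1` is the next step. Its change from compound 2 is 3-fluorophenyl in place of 4-methylphenyl on a saturated ring carbon. Among the compounds with values here, the only measured step that bears on it is the one from compound 1 to compound 2, which exchanged one aryl group for another at the same place and left this assay unchanged within the scatter. On that basis no step beyond the scatter is expected in this assay for compound 3, and the estimated step of no change at the digits printed from compound 2 to compound 3 (within the scatter) is accordingly flat. Compound 3 is therefore expected to read 100%, with a range from 88% to 100%.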

Compound 3, a percentage reported as activity, at one concentration (the size of the read-out at that concentration, not a potency): 100%
Beside the measured number, compound 3's estimate shows no gap at the digits printed; the range from low to high includes it.
By their numbers in this assay, from the lowest: compounds 1, 2 and 3 (each within the scatter of the next).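

In this assay, 3-fluorophenyl in place of 4-methylphenyl on the saturated ring carbon gives no change at the digits printed from compound 2 to compound 3 (within the scatter), so this position has now carried a third aryl group without any reading moving beyond the scatter. Fluoro in place of hydroxy on an aromatic carbon leaves the rest of the aryl group untouched. This exchange gives no change at the digits printed from compound 1 to compound 3 (within the scatter), which extends the flat picture to a change of the aromatic substituent alone. Nothing available explains why these readings coincide.

As far as these compounds go, all three compounds carry a substituted phenyl group at this carbon, so it remains open whether a cyclohexyl group there, or a phenyl ring bearing an amine or a carboxylic acid, would read the same. The readings also come from a single tested concentration, so they leave open whether these compounds would still read alike at other concentrations.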